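The compounds below may be only part of what the source reports. "The series", "measured", "known", "first", "only" and "open" are said of these compounds alone.

Measured in a functional assay on PC-3 cells (Homo sapiens) for cytotoxicity, read by WST assay, with a stated time of 72 h; a lower number here means a stronger inhibitor, a higher number a weaker inhibitor:
- compound 1 `CCCOc1ccc(C2(c3ccc(O)cc3)C(=O)Nc3c2ccc(F)c3F)cc1`: > 1000 nM
- compound 2 `O=C1Nc2c(ccc(F)c2F)C1(c1ccc(O)cc1)C1CCCCCC1`: 12 nM
- compound 3 `Cc1c(F)ccc2c1NC(=O)C2(c1ccc(O)cc1)C1CCCCCC1`: 30 nM

The entry for compound 1 is a limit of the assay and not a number. Of the two true numbers, the higher belongs to compound 3, at 30 nM. Its nearest neighbour is compound 2, and the gap between them is a 2.5-fold higher number from compound 2 to compound 3 (0.40 log units; beyond the scatter).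

Next is compound 4 `COc1ccc2c(c1C)NC(=O)C2(c1ccc(O)cc1)C1CCCCCC1`, which has methoxy in place of fluoro on an aromatic carbon, ortho to a methyl group: methoxy in place of fluoro on an aromatic carbon. Among the measured compounds shown here, only one measured step replaces a fluoro on an aromatic carbon, a 2.5-fold higher number from compound 2 to compound 3 (0.40 log units; beyond the scatter). It is modest and beyond the scatter, but a different group enters there, so it is a loose guide from a single case. A modest move towards a higher number is therefore expected, and the estimated change is a 2.0-fold higher number from compound 3 to compound 4 (0.30 log units; within the scatter). The expected value for compound 4 is 60 nM, with an estimated range from 15 nM to 250 nM.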

Compound 4, half-maximal inhibitory concentration: 12 nM
The estimate for compound 4 lay 5.0-fold (0.70 log units) above the measured number; the measured number lies below the stated range.
By their numbers in this assay, from the lowest: compounds 2 and 4 (each within the scatter of the next); then compound 3. At a limit, above all of these: compound 1.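

Working from this assay, methoxy in place of fluoro on an aromatic carbon, ortho to a methyl group, gives a 2.5-fold lower number from compound 3 to compound 4 (0.40 log units; beyond the scatter). This step runs opposite in direction to the only other replacement of a fluoro in the series, a 2.5-fold higher number from compound 2 to compound 3 (0.40 log units; beyond the scatter), which is made at a different ring position and brings in a different group, so replacing a fluoro here has no single direction across these compounds. Among the compounds shown here, the position also accepts the larger methoxy group without a rise in the number, though nothing measured so far accounts for this step.

Still open, as far as these compounds go, is whether an ethoxy group or an amine at this position would keep the number as low as methoxy does. From the compounds shown here alone, it is also open whether the methoxy step would hold on a ring without the methyl group.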